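Hydroxy in place of fluoro in a weakly cytotoxic series

The source may hold more compounds than are shown below. What is called first, only, known or untested is meant among the compounds shown, and "the series" means these compounds.

Among the measured compounds shown here, compound 1 `Fc1cccc(Nc2nc(-c3cccc(F)c3)nc3ccc(F)cc23)c1` gives 42300 nM in a functional assay on U-937 cells (Homo sapiens) for cytotoxicity, read by MTT assay, with a stated time of 48 h (a lower number here means a stronger inhibitor, a higher number a weaker inhibitor), the only finite number in the set. Compound 2 `Fc1cccc(-c2nc(Nc3ccccc3F)c3cc(F)ccc3n2)c1` returns only a limit, > 50000 nM. Compound 3 `Oc1ccc(Nc2nc(-c3cccc(F)c3)nc3ccc(F)cc23)cc1` likewise returns only the limit > 50000 nM. Both of these sit at the limit of > 50000 nM in this assay, at which 2 of the 3 values shown sit. The step from compound 1 to compound 2 reads an at least 1.1-fold higher number from compound 1 to compound 2 (0.07 log units; that floor lies within the scatter), and the step from compound 1 to compound 3 reads an at least 1.1-fold higher number from compound 1 to compound 3 (0.07 log units; that floor lies within the scatter). Compound 4 `Oc1cccc(Nc2nc(-c3cccc(F)c3)nc3ccc(F)cc23)c1` is not yet measured; it differs from compound 1 by hydroxy in place of fluoro on an aromatic carbon. For the measured compounds named here, the step to compound 3 is the closest precedent, exchanging fluoro for hydroxy as well. Going by the values given here, no measured step moves beyond the scatter, so for compound 4 a small loss or none beyond the scatter is expected, with a 1.4-fold higher number from compound 1 to compound 4 (0.15 log units; within the scatter). Compound 4 is estimated at 60000 nM, within 25000 nM to 150000 nM.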

Compound 4, half-maximal inhibitory concentration: > 50000 nM
Compound 4: no number, only a limit (the forecaster's own chance of this, stated with the estimate: 60%); the middle value does not contradict the limit.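

Replacing 3-fluorophenyl with 3-hydroxyphenyl gives an at least 1.1-fold higher number from compound 1 to compound 4 (0.07 log units; that floor lies within the scatter), so a hydroxy on this ring yields only a limit in this assay at this place as well as in the 4-hydroxyphenyl of compound 3. The steps among compound 2, compound 3 and compound 4 cannot be read, as all three values are limits. Compound 1 remains the only finite value: the limit of > 50000 nM in this assay, at which 3 of the 4 values shown sit.

Going by these compounds, whether hydroxy in place of fluoro here moves the value beyond the scatter stays open. Also open, on these data alone, is how an amine or a carboxylic acid at this place would read in this assay.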